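Nitro in Place of Benzamido: An Expected Shift

The source may hold more compounds than are shown below. What is called first, only, known or untested is meant among the compounds shown, and "the series" means these compounds.

compound 1, `COc1cc(/C=C/C(C)=O)ccc1OCc1cn(-c2c(F)cccc2F)nn1`: 2030 nM
compound 2, `COc1cc(/C=C/C(C)=O)ccc1OCc1cn(-c2c(Cl)cccc2Cl)nn1`: 26600 nM
compound 3, `COc1cc(/C=C/C(C)=O)ccc1OCc1cn(-c2ccc(NC(=O)c3ccccc3)cc2)nn1`: 86700 nM

All three compounds were tested in a functional assay on MCF7 cells (Homo sapiens) for antiproliferative activity, read by MTT assay, with a stated time of 48 h; on this read-out higher numbers stand for weaker inhibition and lower numbers for stronger inhibition. Compound 1 gives 2030 nM, compound 2 gives 26600 nM, and compound 3 gives 86700 nM, the highest number of the three and beyond the scatter from both others.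

Compound 4, `COc1cc(/C=C/C(C)=O)ccc1OCc1cn(-c2ccc([N+](=O)[O-])cc2)nn1`, differs from compound 3 in one place: nitro in place of benzamido on an aromatic carbon. Among the compounds with values here, no measured step exchanges a benzamido for a nitro group, so none bears directly on this change. Within the data shown here, the only measured step, a 13-fold higher number from compound 1 to compound 2 (1.12 log units; beyond the scatter), concerns the same aryl ring but swaps one halogen pair for another; it shows only that a change on that ring can move the number by a large amount. Compounds 1 and 2, whose aryl rings carry no large group, both give lower numbers than compound 3, and compound 4 also carries a small group there. On that basis a lower number than compound 3 is expected for compound 4, though with wide uncertainty. Compound 4 is estimated at 20000 nM, with a range from 5000 nM to 80000 nM. The expected step is a 4.3-fold lower number from compound 3 to compound 4 (0.64 log units; beyond the scatter).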

Compound 4, half-maximal inhibitory concentration: > 100000 nM
Compound 4: no number, only a limit (the forecaster's own chance of this, stated with the estimate: 10%); middle value at least 5.0-fold (0.69 log units) from the limit.
By their numbers in this assay, from the lowest: compound 1; then compound 2; then compound 3. At a limit, above all of these: compound 4.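

In this assay compound 4 gives no number, only a limit of the assay: the limit of > 100000 nM in this assay, at which 1 of the 4 values shown sits. Exchanging benzamido for nitro on this aromatic carbon removes a ring and the amide hydrogen, yet the step reads an at least 1.1-fold higher number from compound 3 to compound 4 (0.06 log units; that floor lies within the scatter), so the result cannot say how far, or whether, the number moved between these two compounds. Against the two halogenated compounds the picture is firmer, with an at least 3.7-fold higher number from compound 2 to compound 4 (0.57 log units; beyond the scatter) and an at least 49-fold higher number from compound 1 to compound 4 (1.69 log units; beyond the scatter), which shows what compound 1 and compound 2 alone could not: a group with few heavy atoms on this aryl ring does not by itself bring a low number, and the low numbers seen so far belong to the 2,6-dihalophenyl rings.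

Going by these compounds, the true value of compound 4 remains unknown, and the comparison with compound 1 and compound 2 changes both the identity and the placement of the substituents, so the two contributions cannot be separated. On these data alone, it also remains open how an amine, a carboxylic acid or a single fluorine in place of nitro on that same aromatic carbon would read in this assay.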